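The source may report more compounds than this note shows. Statements on the series, on what has been measured and on what is new or still open speak of the compounds shown alone.

Three compounds share one core and were tested in a functional assay on MCF7 cells (Homo sapiens) for cytotoxicity, read by MTT assay, with a stated time of 24 h; a lower number here means a stronger inhibitor, a higher number a weaker inhibitor. Compound 1 `CCc1cc(Br)ccc1Nc1ncnc2cc(OC)c(OCCCSc3nc4ccccc4s3)cc12` gives 5870 nM; compound 2 `COc1ccc(Nc2ncnc3cc(OC)c(OCCCSc4nc5ccccc5s4)cc23)cc1` gives 14200 nM; compound 3 `COc1cc2ncnc(Nc3ccc(C)cc3)c2cc1OCCCSc1nc2ccccc2s1` gives 14300 nM. Compound 1 thus has the lowest number of the three, with a 2.4-fold higher number from compound 1 to compound 2 (0.38 log units; beyond the scatter) and a 2.4-fold higher number from compound 1 to compound 3 (0.39 log units; beyond the scatter), while a 1.0-fold higher number from compound 2 to compound 3 (0.00 log units; within the scatter) leaves compounds 2 and 3 indistinguishable.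

Compound 4 `CCc1cc(Br)ccc1Nc1ncnc2cc(OC)c(OCCCSc3nc4ccccc4o3)cc12` is not yet measured. It differs from compound 1 only at the far end of the side chain: 1,3-benzoxazol-2-yl in place of 1,3-benzothiazol-2-yl on a sulfur. Going by the values given here, every measured step so far changed the aryl group on the nitrogen, not this chain end, so none of them bears directly on this change; they show only that moves elsewhere on this core shifted the number by modest amounts. Among the compounds with values here, with no comparable step to draw on, the estimate is that the number stays close to that of compound 1, a step of a 1.0-fold higher number from compound 1 to compound 4 (0.01 log units; within the scatter) that is expected to fall within the scatter. Compound 4 is therefore expected to give about 6000 nM, within a range from 2000 nM to 18000 nM.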

Compound 4, half-maximal inhibitory concentration: 17300 nM
Beside the measured number, compound 4's estimate is 2.9-fold (0.46 log units) below it; low and high end bracket the measured number.
By their numbers in this assay, from the lowest: compound 1; then compounds 2, 3 and 4 (each within the scatter of the next).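

In this assay the group on the sulfur turns out to matter: 1,3-benzoxazol-2-yl in place of 1,3-benzothiazol-2-yl gives a 2.9-fold higher number from compound 1 to compound 4 (0.47 log units; beyond the scatter) and so moves the number beyond the scatter. The earlier steps shown here all changed the aryl group on the nitrogen, whereas this one leaves the counts of heavy atoms, rings and hydrogen-bond acceptors unchanged and exchanges only one sulfur atom for one oxygen atom. Nothing shown explains why this exchange raises the number.

As far as these compounds go, it remains open whether the same exchange would shift the number by a similar amount with 4-methoxyphenyl or 4-methylphenyl on the nitrogen. Also open, from the compounds shown here alone, is how other groups on this sulfur, such as a plain phenyl ring or a pyridine ring, would read.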